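The source may report more compounds than this note shows. Statements on the series, on what has been measured and on what is new or still open speak of the compounds shown alone.

Compound 1, `CCOC(=O)COc1cc(O)c2c(=O)c(O)c(-c3ccc4c(c3)OC(c3ccc(OCC(=O)OCC)c(OC)c3)C(CO)O4)oc2c1`, in a functional assay for inhibition, read by spectrophotometry, with a stated time of 10 min, tested at 150 uM (on this read-out lower numbers stand for less inhibition and higher numbers for more inhibition at the one concentration tested (going by the name of the read-out)), gives 53.5%.
Compound 2, `C=CCOc1cc(O)c2c(=O)c(O)c(-c3ccc4c(c3)OC(c3ccc(OCC=C)c(OC)c3)C(CO)O4)oc2c1`, in this assay gives 72.5%.
Compound 3, `CCN(CC)C(=O)COc1cc(O)c2c(=O)c(O)c(-c3ccc4c(c3)OC(c3ccc(OCC(=O)N(CC)CC)c(OC)c3)C(CO)O4)oc2c1`, in this assay gives 63%.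

All three compounds share one core and differ only in the groups attached to two oxygens on their aromatic rings. Their three numbers in this assay sit close together: the number of compound 3 lies inside the span set by compound 1 and compound 2, and its gap to each of them stays within the usual scatter of this measurement, so none of the three can be called stronger or weaker than another on these data.

Compound 4, `CCN(CC)C(=O)COc1cc(O)c2c(=O)c(O)c(-c3ccc4c(c3)OC(c3ccc(O)c(OC)c3)C(CO)O4)oc2c1`, is not yet measured. It keeps the whole of compound 3 except at one spot, where the change is hydrogen in place of (diethylcarbamoyl)methyl on an oxygen on an aromatic ring. The result is a free hydroxy on that ring where compound 3 carries the longer group.

Among the compounds with values here, no measured pair here shows the effect of removing such a group, so the size and direction of the step can only be guessed. Since the three measured compounds, carrying quite different groups on these oxygens, all land within scatter of each other, the expectation is a step from compound 3 to compound 4 of a number 5 percentage points lower from compound 3 to compound 4 (within the scatter), that is, no change beyond the scatter, with a slight lean toward less inhibition. Compound 4 is therefore expected to give about 58%, most likely within 40% to 76%.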

Compound 4, a percentage reported as inhibition, at one concentration (the size of the read-out at that concentration, not a potency): 52.5%
Beside the measured number, compound 4's estimate is 5.5 percentage points above it; the measured number falls inside the stated range.
By their numbers in this assay, from the lowest: compounds 4, 1, 3 and 2 (each within the scatter of the next, the first and the last beyond it).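

Swapping (diethylcarbamoyl)methyl for hydrogen on an oxygen on an aromatic ring gives the first comparison here in which only one place changes, whereas the earlier compounds differ at two oxygens at once and could not show what a single oxygen contributes. In this assay, the change gives a number 10.5 percentage points lower from compound 3 to compound 4 (beyond the scatter), so what sits on this oxygen does matter: with the group gone and a free hydroxy in its place, inhibition at the one concentration tested is lower, though the step is modest and only slightly exceeds the usual scatter. No measurement available here explains why the number moves.

From the compounds shown here alone, it remains open whether the same step would appear at the other oxygen, which still carries (diethylcarbamoyl)methyl in compound 4, and whether the drop reflects the loss of this particular group or of any group at this position. A methyl, a carboxylic acid on a short chain or an amine at the end of a longer chain on this oxygen would help separate those two possibilities.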